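Swapping the Chlorophenylamino Group for a Pyridinone Ring

This account rests on a few compounds, and the source may have more. Where it says the series, first, only, none or still open, it means among the compounds named here.

Of the compounds shown here, two have been tested in a functional assay for inhibition of sodium/hydrogen exchanger (Oryctolagus cuniculus); on this read-out lower numbers stand for stronger inhibition and higher numbers for weaker inhibition. Compound 1 `Cc1cc(-c2ccc(Cl)cc2)c(S(C)(=O)=O)cc1C(=O)N=C(N)N` gives 45 nM, and compound 2 `Cc1cc(Nc2cccc(Cl)c2)c(S(C)(=O)=O)cc1C(=O)N=C(N)N` gives 33 nM. Among the compounds with values here, compound 2 therefore has the lowest of the two numbers, and its only neighbour is compound 1, separated by a 1.4-fold lower number from compound 1 to compound 2 (0.13 log units; within the scatter). Compound 3 `Cc1cc(-n2ccc(=O)cc2)c(S(C)(=O)=O)cc1C(=O)N=C(N)N` has not yet been measured; it differs from compound 2 as follows: a group of 7 heavy atoms (5 carbon, 1 nitrogen, 1 oxygen; one six-membered aromatic ring with 1 hetero atom) in place of a group of 8 heavy atoms (6 carbon, 1 nitrogen, 1 chlorine; one six-membered aromatic ring of carbon only), on an aromatic carbon. Within the data shown here, no measured step involves the entering group, so nothing directly bears on this change. Among the measured compounds shown here, the one step available, from a 4-chlorophenyl to a (3-chlorophenyl)amino group, stayed within the scatter, which shows that this position has tolerated one exchange. Since the chlorine and the carbon-only ring are both lost here, a modestly weaker result is expected for compound 3, an estimated 4.5-fold higher number from compound 2 to compound 3 (0.66 log units; beyond the scatter). Compound 3 is thus estimated at 150 nM, within a range from 40 nM to 600 nM.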

Compound 3, half-maximal inhibitory concentration: 75 nM
Compound 3: middle estimate off by 2.0-fold (0.30 log units), on the high side; measured number inside the range.
By their numbers in this assay, from the lowest: compounds 2, 1 and 3 (each within the scatter of the next, the first and the last beyond it).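

Replacing the (3-chlorophenyl)amino group with the pyridinone ring gives a 2.3-fold higher number from compound 2 to compound 3 (0.36 log units; beyond the scatter) in this assay, so unlike the earlier exchange at this position, this one shows a real, though modest, change. Set against the 4-chlorophenyl group of compound 1, the same ring gives a 1.7-fold higher number from compound 1 to compound 3 (0.22 log units; within the scatter), so the two cannot be told apart, even though the pyridinone ring has no chlorine and no carbon-only ring. No measurement is available that explains either result.

Going by these compounds, it remains open how a saturated ring such as morpholine, or a small group such as an amine, would behave on this aromatic carbon. A plain pyridine ring would show whether the carbonyl of the pyridinone matters to inhibition here.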